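The compounds below may be only part of what the source reports. "The series", "measured", "known", "first", "only" and "open" are said of these compounds alone.

In a functional assay on KB 3-1 cells (Homo sapiens) for cytotoxicity, read by MTT assay, with a stated time of 68 h (on this read-out lower numbers stand for stronger inhibition and higher numbers for weaker inhibition), compound 1 `O=C(Nc1cccc(-c2ccc(-c3ccccc3)cc2)c1)C(Cl)Cl` reads > 50000 nM, which is a limit of the assay and not a number. Compound 2 `O=C(Nc1cccc(-c2ccc(F)cc2)c1)C(Cl)Cl` gives 26200 nM, the higher of the two actual numbers, and compound 3 `COc1cc(F)cc(-c2cc(NC(=O)C(Cl)Cl)cc(-c3cc(F)cc(OC)c3)c2)c1` gives 5990 nM. Compound 4 `O=C(Nc1cccc(-c2ccc(Cl)cc2)c1)C(Cl)Cl` differs from compound 2 by one swap, chloro in place of fluoro on an aromatic carbon. Within the data shown here, only one measured step bears on this place, an at least 1.9-fold lower number from compound 1 to compound 2 (0.28 log units; that floor lies within the scatter), with fluoro in place of phenyl. Among the measured compounds shown here, it rests on (the limit of > 50000 nM in this assay, at which 1 of the 3 values shown sits), so it gives only a floor, and no chloro compound has been measured yet. The expected step, a 1.5-fold lower number from compound 2 to compound 4 (0.16 log units; within the scatter), therefore stays within the scatter. The estimated value for compound 4 is 18000 nM, with an expected range from 7000 nM to 45000 nM.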

Compound 4, half-maximal inhibitory concentration: 38200 nM
Estimate against measurement, compound 4: 2.1-fold (0.33 log units) below, within the range that was stated.
By their numbers in this assay, from the lowest: compound 3; then compounds 2 and 4 (each within the scatter of the next). At a limit, above all of these: compound 1.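

In this assay, chloro in place of fluoro gives a 1.5-fold higher number from compound 2 to compound 4 (0.16 log units; within the scatter), so this first direct comparison of two halogens at this position shows no difference beyond the scatter. Chloro in place of phenyl gives an at least 1.3-fold lower number from compound 1 to compound 4 (0.11 log units; that floor lies within the scatter), which is only a floor. Compound 1 stands at a limit and not at a number, so the true size of this step stays unknown: the limit of > 50000 nM in this assay, at which 1 of the 4 values shown sits.

On these data alone, how an amine or a carboxylic acid would read at this position remains open. So does whether any group here can give a step beyond the scatter.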